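Aryl Group Swap on the Piperazine Nitrogen

The source may hold more compounds than are shown below. What is called first, only, known or untested is meant among the compounds shown, and "the series" means these compounds.

Two compounds of the series share one core. Compound 1 `CCCc1nc(-c2ccccc2)c(CNCCCN2CCN(c3cccc(F)c3)CC2)o1` and compound 2 `CCCc1nc(-c2ccccc2)c(CNCCN2CCN(C(c3ccccc3)c3ccccc3)CC2)o1` differ in the chain length and in the group on the ring nitrogen. In an assay on HEK293 cells for inhibition of Voltage-dependent T-type calcium channel subunit alpha-1G (Homo sapiens), read by fluorescence, tested at 10 uM (on this read-out lower numbers stand for less inhibition and higher numbers for more inhibition at the one concentration tested (going by the name of the read-out)), compound 1 gives 68.9%, and compound 2 gives 71.9%; the two numbers lie within the scatter of each other, so compound 1 holds the lower of the two numbers only by a margin that means nothing.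

Compound 3 `CCCc1nc(-c2ccccc2)c(CNCCCN2CCN(c3ccccc3C)CC2)o1` is not yet measured. It differs from compound 1 in one place: 2-methylphenyl in place of 3-fluorophenyl on an amine nitrogen in a ring. Within the data shown here, no measured pair isolates a change of this kind, so nothing here points to a shift in either direction. The expected step of a number 2.9 percentage points lower from compound 1 to compound 3 (within the scatter) is small and within the scatter. Compound 3 is therefore estimated at 66% in this assay, with a range from 50% to 80%.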

Compound 3, a percentage reported as inhibition, at one concentration (the size of the read-out at that concentration, not a potency): 54.5%
Beside the measured number, compound 3's estimate is 11.5 percentage points above it, within the range that was stated.
By their numbers in this assay, from the lowest: compound 3; then compounds 1 and 2 (each within the scatter of the next).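

Among these compounds, with the shared core and the propyl-linked chain unchanged, 2-methylphenyl in place of 3-fluorophenyl on the amine nitrogen in the ring gives a number 14.4 percentage points lower from compound 1 to compound 3 (beyond the scatter) in this assay, the first step that isolates this position. The outcome at this position therefore depends on the aryl group it carries, even though the two groups match in heavy-atom count, hydrogen-bond donors and acceptors, and net charge. No available evidence bears on the reason for this step.

The change alters both the substituent and where it sits on the phenyl ring, so the step cannot be assigned to either alone. Plain phenyl, 2-fluorophenyl and 3-methylphenyl at this position would separate the two, and whether the step holds with a shorter chain remains open.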